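The source may hold more compounds than are shown below. What is called first, only, known or untested is meant among the compounds shown, and "the series" means these compounds.

Values in a functional assay on KBVIN cells (Homo sapiens) for antiproliferative activity, read by sulforhodamine B assay, with a stated time of 3 days (a lower number here means that less compound is needed, a higher number that more compound is needed for the effect), so far:
- compound 1 `CCOc1ccc(-c2cc(=O)c3c(o2)C(CC)(CC)C(=O)C(CC)=C3O)cc1` gives 7.54 uM
- compound 2 `CCC1=C(O)c2c(oc(-c3ccc(Br)cc3)cc2=O)C(CC)(CC)C1=O` gives 15.7 uM
- compound 3 `CCC1=C(O)c2c(oc(-c3ccc(F)cc3)cc2=O)C(CC)(CC)C1=O` gives 1.85 uM

Compound 3 has the lowest number of the three, so it needs the least compound for the effect. Compound 4 `CCC1=C(O)c2c(oc(-c3ccccc3C)cc2=O)C(CC)(CC)C1=O` differs from it in one place, with 2-methylphenyl in place of 4-fluorophenyl on an aromatic carbon. Among the compounds with values here, two measured steps bear on this, and both are modest: a 4.1-fold lower number from compound 1 to compound 3 (0.61 log units; beyond the scatter) and an 8.5-fold lower number from compound 2 to compound 3 (0.93 log units; beyond the scatter) are the moves that end at the fluoro compound. Seen from compound 3, each other group measured at this place goes with a higher number. Within the data shown here, no measured compound carries a 2-methylphenyl, so these steps are only a loose guide. A modest move upward is therefore expected, and the estimated change is a 3.2-fold higher number from compound 3 to compound 4 (0.51 log units; beyond the scatter) in this assay for now. The estimate for compound 4 is 6 uM with an expected range from 2 uM to 18 uM here.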

Compound 4, concentration for half-maximal effect: 2.41 uM
Estimate against measurement, compound 4: 2.5-fold (0.40 log units) above; measured number inside the range.
By their numbers in this assay, from the lowest: compounds 3 and 4 (each within the scatter of the next); then compound 1; then compound 2.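

In this assay, within the data shown here, this place accepts 2-methylphenyl, the first group here that is not a 4-substituted phenyl, and the change shows as a 1.3-fold higher number from compound 3 to compound 4 (0.11 log units; within the scatter) and so amounts to no real difference. The same group compares better with the other two, with a 6.5-fold lower number from compound 2 to compound 4 (0.81 log units; beyond the scatter) and a 3.1-fold lower number from compound 1 to compound 4 (0.50 log units; beyond the scatter) in this assay, so a low number at this place is not tied to 4-fluorophenyl alone. Nothing available explains why these groups differ.

Compound 4 differs from the others in both the substituent and where it sits on the phenyl ring, so a 4-methylphenyl or 2-fluorophenyl group would be needed to separate those two changes. Going by these compounds, how a plain phenyl, or a phenyl carrying an amine, would behave at this place also stays open.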